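The source may report more compounds than this note shows. Statements on the series, on what has been measured and on what is new or still open speak of the compounds shown alone.

Of the compounds shown here, two have been measured in a functional assay on HL-60 cells (Homo sapiens) for antiproliferative activity, read by MTT assay, with a stated time of 48 h; on this read-out lower numbers stand for stronger inhibition and higher numbers for weaker inhibition. Compound 1 `CC(=O)O[C@]1(C)/C=C/C(=O)/C(CO)=C\C[C@](C)(CCC=C(C)C)/C=C/[C@H]1OC(=O)C=C(C)C` gives 2370 nM, while compound 2 `CC(C)=CCC[C@]1(C)/C=C/[C@@H](OC(=O)C=C(C)C)[C@](C)(O)/C=C/C(=O)/C(CCl)=C\C1` gives 160 nM, the lowest of the two numbers and a gap that lies beyond the scatter of this assay. Compound 3 `CC(C)=CCC[C@]1(C)/C=C/[C@@H](OC(=O)C=C(C)C)[C@](C)(O)/C=C/C(=O)/C(Cn2cc(CO)nn2)=C\C1` has not yet been measured. It differs from compound 2 by a single change: 4-(hydroxymethyl)-1H-1,2,3-triazol-1-yl in place of chloro on a saturated chain carbon bound to a double-bonded ring carbon. Within the data shown here, with no measured step of this kind to lean on, a clear rise in the number is expected, so that the step of a 19-fold higher number from compound 2 to compound 3 (1.27 log units; beyond the scatter) is estimated to go beyond the scatter. Compound 3 is therefore expected to give about 3000 nM, within a range from 500 nM to 20000 nM.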

Compound 3, half-maximal inhibitory concentration: 3200 nM
For compound 3 the middle estimate is 1.1-fold (0.03 log units) below the measured one; low and high end bracket the measured number.
By their numbers in this assay, from the lowest: compound 2; then compounds 1 and 3 (each within the scatter of the next).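

In this assay, putting 4-(hydroxymethyl)-1H-1,2,3-triazol-1-yl in place of chloro on this saturated chain carbon bound to a double-bonded ring carbon gives a 20-fold higher number from compound 2 to compound 3 (1.30 log units; beyond the scatter) on an otherwise unchanged core. Among these compounds, this is the first single-place step at this position, and it shows that the number here depends strongly on the group carried. Nothing measured here explains the step. The compounds shown leave open how an amine or an azide would read at this place, and whether a triazole bearing a carboxylic acid or a longer chain would read differently.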